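The source may hold more compounds than are shown below. What is called first, only, known or untested is meant among the compounds shown, and "the series" means these compounds.

Measured in a functional assay on PC-3 cells (Homo sapiens) for antiproliferative activity, read by CCK-8 assay, with a stated time of 6 days; a higher number here means a weaker inhibitor, a lower number a stronger inhibitor:
compound 1 `CCN(c1ccc(C#N)c(Cl)c1)c1cc(-c2ccncc2)ccc1C`: 3580 nM
compound 2 `CCN(c1ccc(C#N)c(Cl)c1)c1cc(-c2ccccc2)ccc1C`: "not determined" (no result reported)
compound 3 `CCN(c1ccc(C#N)c(Cl)c1)c1cc(-c2cn[nH]c2)ccc1C`: 15300 nM

Of the two numbers available, the higher belongs to compound 3, at 15300 nM, which makes it the weaker inhibitor of the pair. Compound 1 stands at 3580 nM, while compound 2 offers no number for comparison.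

The next compound, compound 4 `CCN(c1ccc(C#N)c(Cl)c1)c1cc(-c2cccnc2)ccc1C`, keeps the shared core and carries pyridin-3-yl in place of 1H-pyrazol-4-yl on an aromatic carbon, (pyridin-3-yl in place of 1H-pyrazol-4-yl on an aromatic carbon). Going by the values given here, only one measured step bears on this change: a 4.3-fold higher number from compound 1 to compound 3 (0.63 log units; beyond the scatter), where 1H-pyrazol-4-yl replaced pyridin-4-yl. The change to compound 4 runs the other way, from the same 1H-pyrazol-4-yl back to a pyridine ring, although the pyridin-3-yl group itself has not been measured on this core. A step of similar size but opposite direction, towards a lower number in this assay, is therefore expected, with no guarantee that it fully matches the earlier one. The expected change is a 3.4-fold lower number from compound 3 to compound 4 (0.53 log units; beyond the scatter). The estimate for compound 4 is 4500 nM, with an expected range of 1800 nM to 11000 nM.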

Compound 4, half-maximal inhibitory concentration: 11000 nM
Compound 4: middle estimate off by 2.4-fold (0.39 log units), on the low side; low and high end bracket the measured number.
By their numbers in this assay, from the lowest: compound 1; then compounds 4 and 3 (each within the scatter of the next).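

In this assay, pyridin-3-yl in place of pyridin-4-yl gives a 3.1-fold higher number from compound 1 to compound 4 (0.49 log units; beyond the scatter) and so shows that, at this place on the ring, meta to a large group and para to a methyl group, the result depends on where the pyridine ring is attached and not merely on a pyridine ring being present. Pyridin-3-yl in place of 1H-pyrazol-4-yl gives a 1.4-fold lower number from compound 3 to compound 4 (0.14 log units; within the scatter) and so leaves these two groups unseparated in this assay, even though the ring size changes and the hydrogen-bond donor leaves, which makes compound 1 the only one of the three with a step beyond the scatter to both others. No measured evidence on these compounds explains why the pyridin-4-yl group stands apart from the other two.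

Steps involving compound 2 cannot be read, so these compounds do not show how an all-carbon ring at this place compares with the rings containing nitrogen. They also leave open whether pyridin-2-yl, or a pyridin-4-yl ring carrying an amine or a carboxylic acid, would keep, lose or improve on the number of compound 1.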